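Aryl ketone swap on the shared core: compound 4

The compounds below may be only part of what the source reports. "The series", "measured", "known", "first", "only" and "open" are said of these compounds alone.

Three enone-pyrazole analogues differing in the aryl ketone have been run in a functional assay on MDA-MB-231 cells (Homo sapiens) for cytotoxicity, read by sulforhodamine B assay, with a stated time of 48 h, tested at 10 uM; on this read-out lower numbers stand for a stronger effect and higher numbers for a weaker effect at the one concentration tested. Compound 1 `COc1cc(-c2cc(/C=C/C(=O)c3ccc(N)cc3)[nH]n2)cc(OC)c1OC` gives 7% and compound 3 `COc1ccc(-c2cc(/C=C/C(=O)c3cc(OC)c(OC)c(OC)c3)[nH]n2)cc1OC` gives 11%. Compound 2 `COc1cc(-c2cc(/C=C/C(=O)c3ccc(Cl)c(Cl)c3)[nH]n2)cc(OC)c1OC` gives 47%, the highest of the three numbers and thus the weakest effect here, with compound 3 nearest and compound 1 furthest, both beyond the scatter.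

Compound 4 `COc1ccc(C(=O)/C=C/c2cc(-c3cc(OC)c(OC)c(OC)c3)n[nH]2)cc1` differs from compound 2 in one place: 4-methoxyphenyl in place of 3,4-dichlorophenyl on a carbonyl carbon. Among the measured compounds shown here, the one measured step at this position is a number 40 percentage points higher from compound 1 to compound 2 (beyond the scatter), a large rise when the dichlorophenyl enters. Compound 4 removes that group again and puts in an oxygen-bearing aryl ring; compound 3, which also carries an oxygen-bearing aryl ring on its carbonyl, sits at 11%. A step back down, beyond the scatter, is therefore expected in this assay.

Compound 4 is estimated at 15%, with a range from 5% to 40%, which means an expected step of a number 32 percentage points lower from compound 2 to compound 4 (beyond the scatter).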

Compound 4, a percentage reported as activity, at one concentration (the size of the read-out at that concentration, not a potency): -33%
For compound 4 the middle estimate is 48 percentage points above the measured one, outside the stated range (below it).
By their numbers in this assay, from the lowest: compound 4; then compounds 1 and 3 (each within the scatter of the next); then compound 2.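

Within this assay, the aryl group on a carbonyl carbon proves to be more than a choice between the 3,4-dichlorophenyl and a lower level shared by rings without chlorine: 4-methoxyphenyl in place of 3,4-dichlorophenyl gives a number 80 percentage points lower from compound 2 to compound 4 (beyond the scatter) in this series, and methoxy in place of amino on an aromatic carbon still gives a number 40 percentage points lower from compound 1 to compound 4 (beyond the scatter) on top of the earlier drop. Among the compounds shown here, the read-out thus separates two rings without chlorine, and compound 4 at -33% is a negative number, which no earlier compound gave. Nothing available here explains this change.

On these data alone, whether hydroxy, ethoxy or dimethylamino in place of the methoxy would keep the number near that of compound 4 or return it toward that of compound 1 remains open. As far as these compounds go, what a number under zero stands for in these cells also remains open.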